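This account rests on a few compounds, and the source may have more. Where it says the series, first, only, none or still open, it means among the compounds named here.

Compound 1 `CCCCCCCC/C=C\CCCCCCC(=O)c1ncc(-c2ccccc2)o1` is one of three compounds examined in an assay on isolated protein for inhibition of Fatty-acid amide hydrolase 1 (Homo sapiens); a higher number here means a weaker inhibitor, a lower number a stronger inhibitor. Compound 1 gives 320 nM, the lowest of the two numbers reported. Compound 2 `CCCCCCCC/C=C\CCCCCCC(=O)c1nnc(-c2ccccn2)o1` gives 3000 nM in this assay, a value that lies beyond the scatter from that of compound 1. Compound 3 `CCCCCCCC/C=C\CCCCCCC(=O)c1nc2cc(C)ccc2o1` records > 100000 nM, a limit of the assay rather than a number; this is the limit of > 100000 nM in this assay, at which 1 of the 3 values shown sits. Compound 4 `CCCCCCCC/C=C\CCCCCCC(=O)c1ncc(-c2cccnc2)o1` has not yet been measured. It differs from compound 1 in one place: pyridin-3-yl in place of phenyl on an aromatic carbon. Within the data shown here, no measured pair shows this change; the expectation rests on compound 1 alone. The step of a 5.3-fold lower number from compound 1 to compound 4 (0.73 log units; beyond the scatter) is estimated to lower the number beyond the scatter. Compound 4 is expected to give 60 nM, within 15 nM to 250 nM.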

Compound 4, inhibition constant: 61 nM
Estimate against measurement, compound 4: 1.0-fold (0.01 log units) below, and the stated range covers the measured number.
By their numbers in this assay, from the lowest: compound 4; then compound 1; then compound 2. At a limit, above all of these: compound 3.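

Pyridin-3-yl in place of phenyl, on the aromatic carbon next to the ring oxygen, gives a 5.2-fold lower number from compound 1 to compound 4 (0.72 log units; beyond the scatter) in this assay. Among these compounds, this shows that the position responds to a change within the ring it carries, which the earlier compounds could not show, since none of them formed a pair differing in one place. Nothing measured here accounts for the step. The compounds shown leave open how pyridin-4-yl would compare with pyridin-3-yl at this position. They also leave open whether an amine or a carboxylic acid on that ring would keep the gain.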